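The source may hold more compounds than are shown below. What is called first, only, known or untested is meant among the compounds shown, and "the series" means these compounds.

Measured compounds:
Compound 1, `CCCCCNc1nc(Nc2ccc([N+](=O)[O-])cc2)nc(OCC(F)(F)F)n1`: in an ADME assay on microsomes from liver (Homo sapiens) for metabolic stability, with a stated time of 10 min (on this read-out lower numbers stand for a less stable compound and higher numbers for a more stable compound), compound 1 gives 74%.
Compound 2, `CNC(=O)NCCS(=O)(=O)NC(=O)c1ccc(Nc2nc(NC3(c4ccc(Cl)cc4)CC3)nc(OCC(F)(F)F)n2)cc1`: in this assay compound 2 gives 97%.
Compound 3, `CC(C)(C)CNCCS(=O)(=O)NC(=O)c1ccc(Nc2nc(NC3(c4ccc(Cl)cc4)CC3)nc(OCC(F)(F)F)n2)cc1`: in this assay compound 3 gives 89%.

Compound 2 has the highest of the three numbers. For the measured compounds named here, its nearest neighbour is compound 3, a step of a number 8 percentage points lower from compound 2 to compound 3 (within the scatter), which stays within the scatter; the gap to compound 1 is beyond the scatter, and no step is described for that pair, so only the two values themselves speak.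

Compound 4, `CC(C)NC(=O)NCCS(=O)(=O)NC(=O)c1ccc(Nc2nc(NC3(c4ccc(Cl)cc4)CC3)nc(OCC(F)(F)F)n2)cc1`, has not yet been measured. It differs from compound 2 by isopropyl in place of methyl on an amide-type nitrogen. Going by the values given here, the only measured step that touches the same part of the molecule is the one from compound 2 to compound 3, where neopentyl replaced methylcarbamoyl on an amine nitrogen, a larger rearrangement than the present one, and it gave a number 8 percentage points lower from compound 2 to compound 3 (within the scatter). Since that bigger change stayed within the scatter, a smaller exchange of methyl for isopropyl is expected to give no step beyond the scatter in this assay, with an expected step of a number 4 percentage points lower from compound 2 to compound 4 (within the scatter). For compound 4 the estimate in this assay is 93%, with a range from 82% to 100%.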

Compound 4, percent of the compound remaining: 100%
For compound 4 the middle estimate is 7 percentage points below the measured one; the measured number falls inside the stated range.
By their numbers in this assay, from the lowest: compound 1; then compounds 3, 2 and 4 (each within the scatter of the next, the first and the last beyond it).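

In this assay, for the compounds shown here, exchanging methyl for isopropyl on the amide-type nitrogen gives a number 3 percentage points higher from compound 2 to compound 4 (within the scatter), so this position takes a group with two more carbons without a step beyond the scatter, and the earlier compounds held no such exchange on this nitrogen. With the (isopropylcarbamoyl)amino group in place, the comparison with the amine series gives a number 11 percentage points higher from compound 3 to compound 4 (beyond the scatter), the first step among these closely related compounds to pass the scatter, though only modestly, whereas methylcarbamoyl and neopentyl on that nitrogen had stayed within it. Nothing given here accounts for these numbers.

The compounds shown leave open whether a tert-butyl group, a cyclopropyl ring or a longer chain on the same amide-type nitrogen would keep the number in the same range. They also leave open how a carboxylic acid or a primary amine at the end of this side chain would read in this assay.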